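From Bromo to Nitro on a Shared Core

The source may report more compounds than this note shows. Statements on the series, on what has been measured and on what is new or still open speak of the compounds shown alone.

Compound 2 `Cc1ccccc1Nc1nnc(Nc2nc(-c3ccc(Br)cc3)cs2)s1` was tested in a functional assay on the whole organism (strain albino) with Mus musculus as the target, in the maximal electroshock model, with a stated time of 0.5 h (a lower number here means that less compound is needed, a higher number that more compound is needed for the effect), where compound 2 gives 300 mg/kg. Its nearest neighbour is compound 1 `Cc1ccccc1Nc1nnc(Nc2nc(-c3ccc(Cl)cc3)cs2)s1`, which in this assay gives 300 mg/kg; the two stand level, since the step of no change at the digits printed from compound 1 to compound 2 (within the scatter) lies within the scatter. Compound 3 `Cc1ccccc1Nc1nnc(Nc2nc(-c3ccc([N+](=O)[O-])cc3)cs2)s1` has not yet been measured. It differs from compound 2 in one place: nitro in place of bromo on an aromatic carbon. Within the data shown here, no measured step brings in a nitro group, so the only guide is the exchange of chloro for bromo, which moved nothing within this small set. The same outcome is therefore expected here, a step of about no change at the digits printed from compound 2 to compound 3 (within the scatter) in this assay, with no direction beyond the scatter. Compound 3 is accordingly estimated to give 300 mg/kg, within a range from 100 mg/kg to 600 mg/kg.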

Compound 3, minimum effective dose: 100 mg/kg
For compound 3 the middle estimate is 3.0-fold (0.48 log units) above the measured one, and the stated range covers the measured number.
By their numbers in this assay, from the lowest: compound 3; then compounds 1 and 2 (each within the scatter of the next).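

The ring position carrying the halogen is not indifferent in this assay: chloro and bromo had stood level, but nitro in place of bromo gives a 3.0-fold lower number from compound 2 to compound 3 (0.48 log units; beyond the scatter) and nitro in place of chloro gives a 3.0-fold lower number from compound 1 to compound 3 (0.48 log units; beyond the scatter). Less compound is therefore needed with the 4-nitrophenyl group than with either halogenated ring, although both steps are modest and this single compound carries the whole finding. Nothing available bears on why nitro differs from the two halogens.

The compounds shown leave open whether a nitrile, an amine or a carboxylic acid at this place would match nitro, or whether fluoro would stand with chloro and bromo. They also leave open whether the same step would hold with a different group elsewhere on the shared core.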